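The compounds below may be only part of what the source reports. "The series", "measured", "known", "first", "only" and "open" are said of these compounds alone.

For the measured compounds named here, only two compounds built on the shared core have been tested so far, compound 1 `COc1cc(OC)cc([C@@H]2C(O)c3cc(OC)cc(OC)c3[C@H]2c2ccc(F)cc2)c1` and compound 2 `COc1ccc([C@@H]2c3c(OC)cc(OC)cc3C(SCc3ccccc3)[C@H]2c2cc(OC)cc(OC)c2)cc1`. In a functional assay on RAW264.7 cells (Mus musculus) for inhibition, with stated times of 2 h and 24 h (a lower number here means a stronger inhibitor, a higher number a weaker inhibitor), compound 1 is reported as "not active" (no number reported), with no number attached. In this assay, compound 2 gives > 200000 nM, which is a limit of the assay and not a number. Neither result therefore gives a measured potency, and compound 2 offers only a starting line, not a firm point to step from.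

The next compound, compound 3 `COc1ccc([C@@H]2c3c(OC)cc(OC)cc3C(C(O)c3ccc(C)cc3)[C@H]2c2cc(OC)cc(OC)c2)cc1`, differs from compound 2 in one place: hydroxy(4-methylphenyl)methyl in place of benzylsulfanyl on a saturated ring carbon. In words, hydroxy(4-methylphenyl)methyl stands in place of benzylsulfanyl on a saturated ring carbon. Going by the values given here, no measured pair in this small set shows what a single change does here, so any expectation is rough. The expected change, an at least 2.0-fold lower number from compound 2 to compound 3 (0.30 log units; that floor lies within the scatter), is a modest one toward stronger inhibition, and a result that again reports only a limit would fit as well. For compound 3 the estimated value is 100000 nM, with an expected range from 25000 nM to 200000 nM.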

Compound 3, half-maximal inhibitory concentration: 26500 nM
Estimate against measurement, compound 3: 3.8-fold (0.58 log units) above, and the stated range covers the measured number.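

In this assay, putting hydroxy(4-methylphenyl)methyl in place of benzylsulfanyl on a saturated ring carbon gives an at least 7.5-fold lower number from compound 2 to compound 3 (0.87 log units; beyond the scatter). For the compounds shown here, compound 3, at 26500 nM, is the first compound on the shared core with a measured number in this assay, so it shows that a group at this position can go together with measurable inhibition, which neither earlier compound could show. The step gives only a minimum size rather than an exact one, because compound 2 supplies a limit and not a number as its starting point: the limit of > 200000 nM in this assay, at which 1 of the 3 values shown sits.

This single step replaces the sulfur link with a carbon bearing a hydroxy group and also brings a methyl group onto the aromatic ring, so the compounds shown cannot say which of these parts goes with the lower number. Going by these compounds, it also remains open whether an amine, a carboxylic acid or a longer chain on this saturated ring carbon would give a number lower or higher than that of compound 3.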